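The source may report more compounds than this note shows. Statements on the series, on what has been measured and on what is new or still open speak of the compounds shown alone.

Measured compounds:

compound 1, `Cc1ccc(SCc2ccc(/C=C/C(=O)Nc3ccccc3N)cc2)cc1`, 43.4%
compound 2, `Nc1ccccc1NC(=O)c1ccc(CSc2ccc(Cl)cc2)cc1`, 47.3%

In a functional assay on A549 cells (Homo sapiens) for inhibition, read by CCK-8 assay, with a stated time of 72 h, tested at 2 uM (a lower number here means less inhibition of growth, a higher number more inhibition of growth at the concentration tested), compound 1 gives 43.4%. Going by the values given here, compound 2, the only other measured compound, gives 47.3% in this assay. These two numbers lie within the scatter of each other, so compound 1 cannot be called more or less active than compound 2; the two simply sit at about the same level.

The compound not yet measured is compound 3, `CCc1ccc(SCc2ccc(/C=C/C(=O)Nc3ccccc3N)cc2)cc1`. It differs from compound 1 in one place: methyl in place of hydrogen on a saturated chain carbon bound to an aromatic carbon. Among the compounds with values here, no step between two measured compounds shows what this particular change does, so there is no direct guide from the data. With only one extra carbon added at the edge of the molecule, the expected step in this assay is small, with no clear direction and most likely none beyond the scatter. The step is estimated as a number 1.6 percentage points higher from compound 1 to compound 3 (within the scatter). Compound 3 is therefore expected to give about 45% in this assay, with a range from 30% to 60%.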

Compound 3, percent growth inhibition at one concentration: 60.7%
Compound 3: the middle estimate sits 15.7 percentage points below what was measured, and the stated range ends below it.
By their numbers in this assay, from the lowest: compounds 1 and 2 (each within the scatter of the next); then compound 3.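

Changing methyl to ethyl, with the new methyl on a saturated chain carbon bound to an aromatic carbon, gives a number 17.3 percentage points higher from compound 1 to compound 3 (beyond the scatter) in this assay and shows that this position is not indifferent. Compound 1 and compound 2 could not show this, since they differ in more than one place. A single added carbon on the 4-methylphenyl group is enough here to change growth inhibition at the concentration tested, but nothing available explains why.

As far as these compounds go, whether a longer chain such as propyl would raise the number further or lower it remains open, as does whether a branched isopropyl group or a methoxy group would match ethyl. This single step also leaves open whether the same change would act alike on other compounds.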